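The compounds below may be only part of what the source reports. "The series", "measured", "known", "first", "only" and "open" are said of these compounds alone.

Compound 1 `O=C1C=CCC(/C=C/c2ccc(C(F)(F)F)cc2)N1` gives 128 uM in a functional assay on 786-0 cells (Homo sapiens) for inhibition, read by sulforhodamine B assay, with a stated time of 48 h; a higher number here means a weaker inhibitor of growth, a lower number a stronger inhibitor of growth.
Compound 2 `COc1ccc(/C=C/C2CC=CC(=O)N2)cc1` reaches only the limit of > 1090 uM in this assay.
Compound 3 `COc1ccc(/C=C/C2CC=CC(=O)N2)c(OC)c1` likewise reaches only the limit of > 964 uM in this assay.

Compound 2 thus stands at a limit rather than at a number: from the measured value of compound 1, the step of an at least 8.5-fold higher number from compound 1 to compound 2 (0.93 log units; beyond the scatter) runs up to the limit, and compound 2 sits at the limit of > 1090 uM in this assay, at which 1 of the 3 values shown sits. The next compound, compound 4 `COc1ccc(/C=C/C2CC=CC(=O)N2)cc1OC`, differs from compound 2 in one place: methoxy in place of hydrogen on an aromatic carbon. Among the measured compounds shown here, the only measured step of the same kind is a step that the two limits leave unreadable from compound 2 to compound 3, which runs between two limits, one at the limit of > 1090 uM in this assay, at which 1 of the 3 values shown sits, and one at the limit of > 964 uM in this assay, at which 1 of the 3 values shown sits, so its size cannot be read. For the measured compounds named here, the measured compounds therefore give neither a size nor a direction for the step to compound 4; the one comparable change left both values at a limit. For compound 4 the step that the limit leaves unreadable from compound 2 to compound 4 is expected to stay within the scatter. Compound 4 is estimated at 1100 uM, within 300 uM to 4000 uM, and this assay is most likely to report again only a limit.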

Compound 4, concentration for growth inhibition (reported as GI): > 964 uM
Compound 4: a limit, no number (the forecaster's own chance of this, stated with the estimate: 75%); the middle value does not contradict the limit.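

Compound 2 and compound 4 both stand only at limits in this assay, so the step between them cannot be read. The compounds shown leave open whether methoxy in place of hydrogen on an aromatic carbon shifts growth inhibition at all, and in which direction.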